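This account rests on a few compounds, and the source may have more. Where it says the series, first, only, none or still open, it means among the compounds named here.

Series of bicyclic amines with a thiophene-methyl arm, compared in an ADME assay on MDCK cells (Canis lupus familiaris) for cytotoxicity, read by microscopy, with a stated time of 48 h; on this read-out higher numbers stand for lower toxicity in this test and lower numbers for higher toxicity in this test. Compound 1, `CCc1ccc(CN[C@@H]2C[C@H]3C[C@@H]([C@H]2C)C3(C)C)s1`, gives 1560 nM in this assay. Compound 2, `C[C@H]1[C@H](NCc2sccc2C2CCCCC2)C[C@H]2C[C@@H]1C2(C)C`, gives 1560 nM in this assay. Compound 3, `CCCc1csc(CN[C@@H]2C[C@H]3C[C@@H]([C@H]2C)C3(C)C)c1`, gives 12500 nM in this assay, the highest number of the three measured compounds; the nearest is compound 1, whose number is beyond the scatter lower, and compound 2 stands equally far below. Compound 1 and compound 2 give the same number, so nothing separates them here.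

Compound 4, `C[C@H]1[C@H](NCc2cc(C3CCCC3)cs2)C[C@H]2C[C@@H]1C2(C)C`, is derived from compound 3 by cyclopentyl in place of propyl on an aromatic carbon. Among the measured compounds shown here, no measured pair in this set shows this change or a change of a ring for a chain, so the size of its effect in this assay is unknown. The cyclopentyl group of compound 4 recalls the cyclohexyl of compound 2, but on a different ring carbon, and compound 2 gives the lower number. A moderate fall below compound 3 is therefore expected for compound 4, estimated at 5000 nM in this assay, with a range from 1500 nM to 12500 nM. The expected step is a 2.5-fold lower number from compound 3 to compound 4 (0.40 log units; beyond the scatter).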

Compound 4, minimum cytotoxic concentration: 1560 nM
Compound 4: the middle estimate sits 3.2-fold (0.51 log units) above what was measured; measured number inside the range.
By their numbers in this assay, from the lowest: compounds 1, 2 and 4 (each within the scatter of the next); then compound 3.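

On an aromatic carbon two ring bonds from the ring sulfur, cyclopentyl in place of propyl gives a step beyond the usual scatter in this assay: an 8.0-fold lower number from compound 3 to compound 4 (0.90 log units; beyond the scatter). Among the compounds shown here, this is the first pair that differs in one place, so it is the first sign that a change at this carbon alone can move the read-out; here the change goes with higher toxicity in this test. No measured data bear on what lies behind this step.

Open, from the compounds shown here alone, is whether the step follows from the ring itself or from the added carbons, which a pentyl chain on this carbon would help to separate. Also open, going by these compounds, is how this assay would read a hydroxyl or an amine on the same carbon.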